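A few compounds are considered here, and "the series" means these few. Any claim that something is new, unique, unknown or untested is made for them only; others in the source may bear on it.

Compound 1 `CC(C)Oc1ccc(-c2cc(C(=O)O)nn2-c2ccc(C(C)C)cc2)cc1` gives 2140 nM in an assay for displacement of a labelled ligand from E3 ubiquitin-protein ligase Mdm2 (Homo sapiens), read by fluorescence polarization, with a stated time of 30 min; on this read-out lower numbers stand for stronger inhibition and higher numbers for weaker inhibition. Compound 2 `CC(C)c1ccc(-n2nc(C(=O)O)cc2-c2ccc(OCc3ccccc3)cc2)cc1` gives 616 nM in this assay; the change between these two, (benzyl in place of isopropyl on an oxygen on an aromatic ring), produced a 3.5-fold lower number from compound 1 to compound 2 (0.54 log units; beyond the scatter). Compound 3 `CC(C)Oc1ccc(C(=O)Nc2c(C(=O)O)nn(-c3ccc(Oc4ccccc4)cc3)c2-c2ccc(OC(C)C)cc2)cc1` is built on a different core, and the difference between the two cores is not broken down here. In this assay compound 3 gives 107 nM, the lowest of the three numbers. Compound 4 `CC(C)Oc1ccc(C(=O)Nc2c(C(=O)O)nn(-c3ccc(Oc4ccccc4)cc3)c2-c2ccc(OCc3ccccc3)cc2)cc1` is not yet measured and differs from compound 3 by benzyl in place of isopropyl on an oxygen on an aromatic ring. The place of this change matches the earlier one word for word, so it is the same change, now applied on the core of compound 3. In this assay a step of a 2.7-fold lower number from compound 3 to compound 4 (0.43 log units; beyond the scatter) is expected, set beside the earlier one. Among the measured compounds shown here, this expectation rests only on the single step of a 3.5-fold lower number from compound 1 to compound 2 (0.54 log units; beyond the scatter), seen on a different core. Compound 4 is estimated at 40 nM, with an expected span from 15 nM to 120 nM.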

Compound 4, inhibition constant: 4470 nM
For compound 4 the middle estimate is 110-fold (2.05 log units) below the measured one, and the stated range ends below it.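

The change from isopropoxy to benzyloxy gives a 42-fold higher number from compound 3 to compound 4 (1.62 log units; beyond the scatter) in this assay, whereas the same change on the other core gave a 3.5-fold lower number from compound 1 to compound 2 (0.54 log units; beyond the scatter). The two steps run in opposite directions and do not agree: the same change on two cores in this assay, a 3.5-fold lower number (0.54 log units; beyond the scatter) from compound 1 to compound 2 and a 42-fold higher number (1.62 log units; beyond the scatter) from compound 3 to compound 4, 150-fold (2.16 log units) apart, beyond the scatter of two such steps. This shows that the change cannot be carried from one of these cores to the other, but with a single pair on each core it does not show which difference between the cores matters.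

Open, on these data alone, is whether a smaller ether such as methoxy, or a cyclohexylmethyl group on the same oxygen, would follow the step on the core of compound 1 or that on the core of compound 3. Also open, as far as these compounds go, is how the change behaves on any third core.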